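A few compounds are considered here, and "the series" means these few. Any claim that something is new, unique, unknown or untested is made for them only; others in the source may bear on it.

Compound 1 `COc1ccnc(-c2cc(Cl)ccc2NS(=O)(=O)c2ccc(C(C)(C)C)cc2)c1` and compound 2 `CC(C)(C)c1ccc(S(=O)(=O)Nc2ccc(Cl)cc2-c2ncccc2CN)cc1` share one core and differ only in the aromatic group attached to it. In a functional assay on isolated protein for antagonist activity at C-C chemokine receptor type 9 (Homo sapiens), read by calcium flux, with a stated time of 10 min (on this read-out higher numbers stand for weaker inhibition and lower numbers for stronger inhibition), compound 1 gives 2500 nM, and compound 2 gives 3160 nM. The step of a 1.3-fold higher number from compound 1 to compound 2 (0.10 log units; within the scatter) shows that exchanging one six-membered aromatic ring with a single hetero atom for another left the read-out essentially unchanged. Compound 1 therefore holds the lower of the two numbers, but the two values lie within the scatter of each other.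

Compound 3 `CC(C)(C)c1ccc(S(=O)(=O)Nc2ccc(Cl)cc2-c2ncnc(CO)c2O)cc1` has not yet been measured. Relative to compound 1 the change is a group of 9 heavy atoms (5 carbon, 2 nitrogen, 2 oxygen; one six-membered aromatic ring with 2 hetero atoms) in place of a group of 8 heavy atoms (6 carbon, 1 nitrogen, 1 oxygen; one six-membered aromatic ring with 1 hetero atom), on an aromatic carbon. Among the compounds with values here, the one measured step that bears on this position is the one from compound 1 to compound 2, and it was within the scatter, so the step of a 1.3-fold higher number from compound 1 to compound 3 (0.11 log units; within the scatter) is expected to be small as well. Compound 3 is estimated to give 3200 nM, with a likely range from 1200 nM to 8500 nM.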

Compound 3, half-maximal inhibitory concentration: 11 nM
Estimate against measurement, compound 3: 290-fold (2.46 log units) above, and the stated range ends above it.
By their numbers in this assay, from the lowest: compound 3; then compounds 1 and 2 (each within the scatter of the next).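

Replacing the ring gives a 230-fold lower number from compound 1 to compound 3 (2.36 log units; beyond the scatter) and a 290-fold lower number from compound 2 to compound 3 (2.46 log units; beyond the scatter) in this assay, so this position, on an aromatic carbon ortho to a large group, is far from indifferent to what it carries. The earlier pair, both with a six-membered aromatic ring with 1 hetero atom, had shown no such sensitivity; the only group that stands apart is the one in compound 3, with its six-membered aromatic ring with 2 hetero atoms, 2 hydrogen-bond donors and 4 hydrogen-bond acceptors. Nothing measured on these compounds gives a reason for the size of this step.

Compound 3 changes the ring and its substituents together, so the compounds shown do not separate their contributions. Going by these compounds, whether a carboxylic acid or an amine on that ring would serve equally remains open.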